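The source may report more compounds than this note shows. Statements on the series, on what has been measured and on what is new or still open speak of the compounds shown alone.

Measured so far:
- compound 1, `CCS(=O)(=O)N(Cc1cccnc1)c1cccc(C(=O)c2ccccc2)c1`: 1100 nM
- compound 2, `CCS(=O)(=O)N(Cc1cccnc1)c1ccc(C(F)c2ccccc2)cc1`: > 30000 nM
- compound 3, `CCS(=O)(=O)N(Cc1cccnc1)c1ccc(COc2ccccc2)cc1`: 2100 nM

In an assay on isolated protein with metabotropic glutamate receptor 2 (Homo sapiens) as the target (a lower number here means that less compound is needed, a higher number that more compound is needed for the effect), compound 1 gives 1100 nM, the lowest of the two numbers obtained. Its nearest neighbour is compound 3, which in this assay gives 2100 nM, a gap that lies within the usual scatter, so the two cannot be ordered. Compound 2 gives only a limit in this assay, > 30000 nM, and not a number. Among the measured compounds shown here, the one step between compounds that differ in a single place runs an at least 14-fold lower number from compound 2 to compound 3 (1.15 log units; beyond the scatter), with one of the three values sitting at the limit of > 30000 nM in this assay, at which 1 of the 3 values shown sits.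

Compound 4, `CCS(=O)(=O)N(Cc1cccnc1)c1cccc(OC(F)(F)F)c1`, is reached from compound 1 by a single change: trifluoromethoxy in place of benzoyl on an aromatic carbon. For the measured compounds named here, this exchange, a trifluoromethoxy group for a benzoyl group, has no measured counterpart among the three compounds, since the only measured step concerns a different pair of groups on a different position of the shared core. The expectation therefore rests on the loss of one six-membered aromatic ring of carbon only and of one double bond outside aromatic rings, which leaves a smaller group in its place. For compound 4 a value of 5000 nM is expected, within a range of 1500 nM to 30000 nM. The step this estimate implies is a 4.5-fold higher number from compound 1 to compound 4 (0.66 log units; beyond the scatter), a higher number, and it is uncertain.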

Compound 4, half-maximal effective concentration: 1600 nM
The estimate for compound 4 lay 3.1-fold (0.49 log units) above the measured number; the measured number falls inside the stated range.
By their numbers in this assay, from the lowest: compounds 1, 4 and 3 (each within the scatter of the next). At a limit, above all of these: compound 2.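

In this assay, putting trifluoromethoxy in place of benzoyl on this aromatic carbon gives a 1.5-fold higher number from compound 1 to compound 4 (0.16 log units; within the scatter), so the two compounds cannot be ordered. Among the compounds shown here, this is the first sign of how much this position can accept: one six-membered aromatic ring of carbon only and the double bond outside aromatic rings both leave, and the number stays within the scatter. The second ring of the benzoyl group is therefore not required here, at least when trifluoromethoxy takes its place, though nothing measured in these compounds explains why the two groups give such similar numbers.

On these data alone, what remains open is how far this acceptance reaches, for instance whether an amine, a carboxylic acid or a longer chain such as n-butoxy on the same carbon would keep the number in this range, or whether a bare hydrogen would do as well. Also open, as far as these compounds go, is whether trifluoromethoxy would give a similar result at the place that carries the phenoxymethyl group in compound 3.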